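This account rests on a few compounds, and the source may have more. Where it says the series, first, only, none or still open, it means among the compounds named here.

Measured compounds:
- compound 1, `OC[C@H]1O[C@@H](n2cnc3c(NCc4ccccc4Cl)ncnc32)[C@H](O)[C@@H]1O`: in a functional assay on B16 cells (Mus musculus) for antiproliferative activity, with a stated time of 72 h (on this read-out higher numbers stand for weaker inhibition and lower numbers for stronger inhibition), compound 1 gives > 166000 nM, a limit of the assay and not a number.
- compound 2, `COc1cccc(CNc2ncnc3c2ncn3[C@@H]2O[C@H](CO)[C@@H](O)[C@H]2O)c1`: in this assay compound 2 gives > 166000 nM, again a limit.
- compound 3, `OC[C@H]1O[C@@H](n2cnc3c(NCc4cc(F)cc(F)c4)ncnc32)C(O)C1O`: in this assay compound 3 gives > 166000 nM, also a limit.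

Going by the values given here, compound 2 therefore stands at the limit in this assay, as do the two other measured values, so no compound can be set above or below another on these numbers. Among the compounds with values here, the one single-point step that is known, a step that the two limits leave unreadable from compound 1 to compound 2, cannot be read in size or direction because of the limit of > 166000 nM in this assay, at which 3 of the 3 values shown sit.

The unmeasured compound 4, `OC[C@H]1O[C@@H](n2cnc3c(NCc4ccc(F)cc4Cl)ncnc32)[C@H](O)[C@@H]1O`, differs from compound 2 by 2-chloro-4-fluorophenyl in place of 3-methoxyphenyl on a saturated chain carbon bound to a nitrogen on an aromatic ring. Within the data shown here, the only step bearing on it is the unreadable step from compound 1 to compound 2, so no size can be taken from it. Given that every measured value sits at the limit, compound 4 is expected to give a further limit in this assay, and the step that the limit leaves unreadable from compound 2 to compound 4 is expected to be no more than a nominal one. The estimate for compound 4 is 200000 nM, with a range from 100000 nM to 600000 nM.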

Compound 4, half-maximal inhibitory concentration: > 166000 nM
Compound 4: no number, only a limit; the forecaster's own chance of this, stated with the estimate: 85%; the middle value does not contradict the limit.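

Compound 4 sits at the same limit as compound 1 and compound 2, so neither new step from those two compounds can be read: the limit of > 166000 nM in this assay, at which 4 of the 4 values shown sit.

The compounds shown leave open whether any substituted benzyl group on the shared core gives a readable value in this assay.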